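The compounds below may be only part of what the source reports. "The series", "measured", "known", "first", "only" and "open" are said of these compounds alone.

This small set of three measured compounds shares one core. Compound 1 `C=C1CN(C)N(c2ccc(C)cc2)C1=O` gives 59100 nM in a functional assay on MCF7 cells (Homo sapiens) for inhibition, read by MTT assay, with a stated time of 48 h; on this read-out lower numbers stand for stronger inhibition and higher numbers for weaker inhibition. Compound 2 `C=C1C(=O)N(c2ccccc2)N(c2ccccc2)C1CC` gives 20000 nM in this assay, the lowest number of the three, and compound 3 `C=C1C(=O)N(c2ccccc2)N(C)C1CC` gives 185000 nM in this assay. Going by the values given here, the only change that can be followed between two measured compounds is a 9.3-fold higher number from compound 2 to compound 3 (0.97 log units; beyond the scatter), a swap of methyl in place of phenyl on an amine nitrogen in a ring.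

Compound 4 `C=CCC1C(=C)C(=O)N(c2ccccc2)N1c1ccccc1` has not yet been measured. It differs from compound 2 by vinyl in place of methyl on a saturated chain carbon bound to a saturated ring carbon. Among the compounds with values here, no measured step touches this part of the molecule: the step from compound 2 to compound 3 alters the ring nitrogen, not the chain carbon, and compound 1 differs from compound 2 in several places at once, so its value alone says nothing about this single change. With nothing in the data pointing either way, the expectation is that replacing methyl with vinyl on the chain carbon gives no step beyond the scatter, so that no change at the digits printed from compound 2 to compound 4 (within the scatter) is estimated to be small. Compound 4 is therefore expected to give about 20000 nM in this assay, with a range from 8000 nM to 50000 nM.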

Compound 4, half-maximal inhibitory concentration: 5100 nM
Compound 4: the middle estimate sits 3.9-fold (0.59 log units) above what was measured; the measured number lies below the stated range.
By their numbers in this assay, from the lowest: compound 4; then compound 2; then compound 1; then compound 3.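

In this assay, vinyl in place of methyl on a saturated chain carbon bound to a saturated ring carbon gives a 3.9-fold lower number from compound 2 to compound 4 (0.59 log units; beyond the scatter), so this chain is a place where adding very little to the molecule moves the read-out. Going by these compounds alone, the only change that could be followed before sat on the ring nitrogen and went towards weaker inhibition, whereas this one, read one bond further out as ethyl to allyl, goes towards stronger inhibition and shows that the core can be improved through this chain as well. Nothing measured here says what lies behind this step.

The compounds shown leave open whether the double bond or the added carbon carries the step, and a propyl chain on this carbon would separate the two. Also open, as far as these compounds go, are whether the step survives with methyl in place of phenyl on the ring nitrogen, as in compound 3, and how a longer chain or an amine on this chain would read.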